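An Aminophenyl Substituent on a Fused Seven-Membered Core

The source may hold more compounds than are shown below. What is called first, only, known or untested is meant among the compounds shown, and "the series" means these compounds.

Compound 1 `COc1cc2c(cc1OC)C(c1ccc(Cl)cc1)=NNC(=O)C2` was tested in a functional assay on the whole organism with Mus musculus as the target (a higher number here means that more compound is needed for the effect, a lower number that less compound is needed), where compound 1 gives 75.3 umol/kg. For the measured compounds named here, that is the highest of the two numbers measured so far. Going by the values given here, compound 2 `COc1cc2c(cc1OC)C(c1ccc(Br)cc1)=NN(C)C(=S)C2` is the only other measured compound; in this assay compound 2 gives 60.4 umol/kg, which lies within the scatter of the figure for compound 1, so the two cannot be ordered. Compound 3 `COc1cc2c(cc1OC)C(c1cccc(N)c1)=NNC(=O)C2` has not yet been measured in this assay. It differs from compound 1 in a single place: 3-aminophenyl in place of 4-chlorophenyl on a carbon with a double bond to nitrogen. Among the compounds with values here, no measured pair shows what this kind of change does on the shared core, so the expectation rests on the two values alone. The step expected here, a 1.2-fold higher number from compound 1 to compound 3 (0.08 log units; within the scatter), is small and carries no confident direction beyond the scatter. Compound 3 is therefore estimated to give 90 umol/kg in this assay, within a range from 40 umol/kg to 220 umol/kg.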

Compound 3, dose for half-maximal effect: 18.3 umol/kg
Estimate against measurement, compound 3: 4.9-fold (0.69 log units) above, and the stated range ends above it.
By their numbers in this assay, from the lowest: compound 3; then compounds 2 and 1 (each within the scatter of the next).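

In this assay, this position proves sensitive to the group it carries, which compounds 1 and 2 could not show, as they differ in more than one place and their values lie within the scatter. Placing 3-aminophenyl in place of 4-chlorophenyl on the carbon with a double bond to nitrogen gives a 4.1-fold lower number from compound 1 to compound 3 (0.61 log units; beyond the scatter), although both groups have the same count of heavy atoms and one six-membered aromatic ring of carbon only. No measurement at hand explains this step.

The change replaces the chlorine with an amine and also alters the substituent's place on the phenyl ring, so 4-aminophenyl and 3-chlorophenyl groups would be needed to separate the two. On these data alone, whether a dimethylamino or acetamido group at the same place on the phenyl ring would keep the lower number also remains open.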